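From carboxy to carbamoyl on the side-chain amine

A few compounds are considered here, and "the series" means these few. Any claim that something is new, unique, unknown or untested is made for them only; others in the source may bear on it.

In a functional assay on SK-BR-3 cells (Homo sapiens) for antiproliferative activity (a higher number here means a weaker inhibitor, a lower number a stronger inhibitor), compound 1 `CCCN(CCC)CCCOc1ccc2cc(NC(=O)c3ccc(O)c(CC=C(C)C)c3)c(=O)oc2c1C` gives > 50000 nM as a limit of the assay. Compound 2 `CC(C)=CCc1cc(C(=O)Nc2cc3ccc(OCCCNCC(C)C)c(C)c3oc2=O)ccc1O` reads 1030 nM in this assay and compound 3 `CC(C)=CCc1cc(C(=O)Nc2cc3ccc(OCCCNCC(=O)O)c(C)c3oc2=O)ccc1O` reads 7570 nM on the same scale. Of the two values that are not limits, compound 3 has the higher, and compound 2 is its nearest neighbour.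

Compound 4 `CC(C)=CCc1cc(C(=O)Nc2cc3ccc(OCCCNCC(N)=O)c(C)c3oc2=O)ccc1O` alters compound 3 at one place: amino in place of hydroxy on a carbonyl carbon with amino in place of hydroxy on a carbonyl carbon, so (carboxymethyl)amino becomes (carbamoylmethyl)amino.

Two measured steps start from a limit: an at least 48-fold lower number from compound 1 to compound 2 (1.68 log units; beyond the scatter) and an at least 6.6-fold lower number from compound 1 to compound 3 (0.81 log units; beyond the scatter) give only a lower bound on size. Within the data shown here, the closest precedent is a 7.3-fold higher number from compound 2 to compound 3 (0.87 log units; beyond the scatter) with carboxy in place of isopropyl. Compound 4 no longer carries the carboxy group of compound 3, so part of that step (a 7.3-fold higher number from compound 2 to compound 3 (0.87 log units; beyond the scatter)) is expected to be recovered, though no primary amide has yet been measured in this series.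

The expected change is a modest move to a lower number, estimated as a 2.5-fold lower number from compound 3 to compound 4 (0.40 log units; beyond the scatter) in this assay and not expected to pass the level of the isobutylamino analogue by much. The estimate for compound 4 is 3000 nM with an expected range from 1000 nM to 9000 nM in this assay.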

Compound 4, half-maximal inhibitory concentration: 2290 nM
Compound 4: middle estimate off by 1.3-fold (0.12 log units), on the high side; the measured number falls inside the stated range.
By their numbers in this assay, from the lowest: compound 2; then compound 4; then compound 3. At a limit, above all of these: compound 1.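

In this assay, amino in place of hydroxy on a carbonyl carbon gives a 3.3-fold lower number from compound 3 to compound 4 (0.52 log units; beyond the scatter), so this position responds to an exchange of one heavy atom, and the earlier comparison with isobutylamino, a 7.3-fold higher number from compound 2 to compound 3 (0.87 log units; beyond the scatter), could not show this because it replaced the whole end of the side chain. The recovery is only partial, since carbamoyl in place of isopropyl still leaves a 2.2-fold higher number from compound 2 to compound 4 (0.35 log units; beyond the scatter), and the three secondary amines now run in the order isobutylamino, (carbamoylmethyl)amino, (carboxymethyl)amino, from the lowest number to the highest. The dipropylamino comparison, an at least 21-fold lower number from compound 1 to compound 4 (1.33 log units; beyond the scatter), gives only a bound on size because compound 1 stands at a limit of the assay: the limit of > 50000 nM in this assay, at which 1 of the 4 values shown sits.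

From the compounds shown here alone, what remains open is whether the gain belongs to the primary amide itself or would extend to a methyl ester, a methylamide or a longer chain between the amine and the carbonyl. Going by these compounds, it is also open whether the dipropylamino result reflects the tertiary amine in general, which a dimethylamino or pyrrolidine side chain would help to test.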